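This account rests on a few compounds, and the source may have more. Where it says the series, first, only, none or still open, it means among the compounds named here.

Compound 1, with the structure `C=CCc1ccc(OCc2cn(-c3ccc(C#N)cc3)nn2)c(O)c1`, carries a cyano group on the phenyl ring that sits on the triazole nitrogen. In a functional assay on HepG2 cells (Homo sapiens) for inhibition, read by MTT assay, with a stated time of 72 h, tested at 30 uM (on this read-out lower numbers stand for less inhibition of growth and higher numbers for more inhibition of growth at the one concentration tested), compound 1 gives 1.5%, and compound 2, `C=CCc1ccc(OCc2cn(-c3ccccc3Cl)nn2)c(O)c1`, gives 2.5%. Within the data shown here, the one measured step, a number 1 percentage points higher from compound 1 to compound 2 (within the scatter), swaps the whole aryl group on the aromatic nitrogen and leaves both numbers close to zero, so the two compounds sit within the scatter of each other. Compound 3, `C=CCc1ccc(OCc2cn(-c3ccc(C(=O)c4ccccc4)cc3)nn2)c(O)c1`, differs from compound 1 in one place: benzoyl in place of cyano on an aromatic carbon. Among the measured compounds shown here, no measured step changes exactly this position, so the step to compound 2 is the only guide, and it shows that altering this aryl group did not move the read-out beyond the scatter. A step of a number 3.5 percentage points higher from compound 1 to compound 3 (within the scatter) is therefore expected, essentially none beyond the scatter. Compound 3 is estimated at 5%, with a range from -5% to 25%.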

Compound 3, percent growth inhibition at one concentration: 14.8%
Compound 3: the middle estimate sits 9.8 percentage points below what was measured; measured number inside the range.
By their numbers in this assay, from the lowest: compounds 1 and 2 (each within the scatter of the next); then compound 3.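

In this assay, among these compounds, benzoyl in place of cyano brings a number 13.3 percentage points higher from compound 1 to compound 3 (beyond the scatter), the first step in this small set to pass beyond the scatter. The earlier change of the whole aryl group stayed within the scatter, so this result gives the first sign that the read-out can respond to what sits on this aromatic carbon, though the rise is modest. The change adds a carbonyl and a six-membered aromatic ring together, and nothing available here explains the rise.

The compounds shown leave open whether the carbonyl or the added ring goes with the higher number, a question that an acetyl group or a phenyl group at this place could help separate. From the compounds shown here alone, how an amine or a carboxylic acid at this place would compare also remains open.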